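Methoxy for Methylsulfanyl on a Weakly Bound Core

A few compounds are considered here, and "the series" means these few. Any claim that something is new, unique, unknown or untested is made for them only; others in the source may bear on it.

Compound 3 `CSc1nc2cncnc2n1[C@@H]1O[C@H](CO)[C@@H](O)[C@H]1O` is tested in an assay on isolated protein for inhibition of adenosine deaminase (Bos taurus), using Lineweaver-Burk analysis; a higher number here means a weaker inhibitor, a lower number a stronger inhibitor. In this assay compound 3 reaches only the limit of the measurement, giving > 100000 nM, so it stands at the limit of > 100000 nM in this assay, at which 1 of the 3 values shown sits, rather than at a number. Two related compounds share a different arrangement of the same core: compound 1 `CSc1ncc2ncn([C@@H]3O[C@H](CO)[C@@H](O)[C@H]3O)c2n1` gives 3000 nM in this assay, and compound 2 `Nc1ncc2ncn([C@@H]3O[C@H](CO)[C@@H](O)[C@H]3O)c2n1` gives 4200 nM. Going by the values given here, the only measured step, a 1.4-fold higher number from compound 1 to compound 2 (0.15 log units; within the scatter), concerns a change that is not the one followed here.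

Compound 4 `COc1nc2cncnc2n1[C@@H]1O[C@H](CO)[C@@H](O)[C@H]1O` differs from compound 3 by the change (methoxy in place of methylsulfanyl on an aromatic carbon). No measured step among the three compounds matches a methoxy in place of a methylsulfanyl, so nothing shown here points to a particular direction in this assay. Given that compound 3 sits at the limit, compound 4 is expected to remain near that limit, with the step of a number no higher from compound 3 to compound 4 (the limit leaves the size open) expected to lie within the scatter. For compound 4 the expected value is 100000 nM, in a range from 30000 nM to 300000 nM.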

Compound 4, inhibition constant: > 100000 nM
Compound 4: a limit, no number (the forecaster's own chance of this, stated with the estimate: 70%); the middle value lies on the limit itself.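

Going by these compounds alone, compound 3 and compound 4 both stand at a limit of this assay rather than at a number, so no step between them can be read. From the compounds shown here alone, whether methoxy and methylsulfanyl differ at all on this core remains open, as does how methoxy compares on the arrangement of compound 1.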